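The source may hold more compounds than are shown below. What is called first, only, known or untested is meant among the compounds shown, and "the series" means these compounds.

Among the compounds with values here, compound 1 `CC(c1ccc(-c2ccccc2)c(F)c1)c1nnc2n1N=C(c1ccc(C(F)(F)F)cc1)CS2` is the one compound in this set that comes with a number. In a functional assay on MCF7 cells (Homo sapiens) for inhibition, read by sulforhodamine B assay, with a stated time of 72 h (on this read-out higher numbers stand for weaker inhibition and lower numbers for stronger inhibition), compound 1 gives 4300 nM. A second compound, compound 2 `CC(c1ccc(-c2ccccc2)c(F)c1)c1n[nH]c(=S)n1N`, is built on a different core, and in this assay compound 2 is recorded as "not active" (no number reported) with no number attached. Compound 1 therefore stands alone as the single quantified entry, and there is no measured neighbour against which its result can be ordered.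

Compound 3 `CC(c1ccc(-c2ccccc2)c(F)c1)c1nnc2n1N=C(c1ccc([N+](=O)[O-])cc1)CS2` has not been measured. It differs from compound 1 in one place: nitro in place of trifluoromethyl on an aromatic carbon. Within the data shown here, no measured pair in this set shows a step of that kind, so the size of the step can only be guessed. The step is expected to be small and, if anything, toward stronger inhibition, with a 1.4-fold lower number from compound 1 to compound 3 (0.16 log units; within the scatter) not expected to exceed the usual scatter. On that basis compound 3 is expected to give an estimated 3000 nM in this assay, with a plausible range from 1000 nM to 12000 nM.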

Compound 3, half-maximal inhibitory concentration: 7800 nM
Beside the measured number, compound 3's estimate is 2.6-fold (0.41 log units) below it, within the range that was stated.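

In this assay, the first step read at this place on the aromatic ring, 4-(trifluoromethyl)phenyl to 4-nitrophenyl, comes out as a 1.8-fold higher number from compound 1 to compound 3 (0.26 log units; within the scatter), so the two compounds cannot be told apart on this read-out. This place now carries two groups with a number each, and exchanging trifluoromethyl for nitro keeps the result inside what repeated measurements of this kind would be expected to give, with the rest of the structure held the same. Nothing available on these compounds bears on why the exchange has so little consequence here.

From the compounds shown here alone, with only these two groups at this place, whether a group of another kind, such as an amine, a carboxylic acid or a plain hydrogen, would give a step beyond the scatter remains open. Within the data shown here, also open is whether a change elsewhere on the shared core would matter more than this one, since the single step read so far belongs to this place alone.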